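The source may hold more compounds than are shown below. What is called first, only, known or untested is meant among the compounds shown, and "the series" means these compounds.

Measured compounds in an assay on FRT cells for positive allosteric modulation of Cystic fibrosis transmembrane conductance regulator variant N1303K (Homo sapiens), in the presence of a further agent that is not named here; a lower number here means that less compound is needed, a higher number that more compound is needed for the effect:
compound 1 `COc1ccc2[nH]c3c(c2c1)CCNC31CCN(Cc2ccc([N+](=O)[O-])cc2F)CC1` gives 5900 nM
compound 2 `COc1ccc2[nH]c3c(c2c1)CCNC31CCN(Cc2ccc(Cl)cc2Cl)CC1` gives 1800 nM
compound 3 `COc1ccc2[nH]c3c(c2c1)CCNC31CCN(Cc2ccc(Br)cc2F)CC1` gives 1600 nM

Compound 2 holds the second-highest number of the three; its nearest neighbour is compound 3 (a 1.1-fold lower number from compound 2 to compound 3 (0.05 log units; within the scatter)), while the furthest is compound 1 (a 3.3-fold lower number from compound 1 to compound 2 (0.52 log units; beyond the scatter)). The next compound is compound 4 `COc1ccc2[nH]c3c(c2c1)CCNC31CCN(Cc2ccc(F)cc2F)CC1`, which differs from compound 2 by 2,4-difluorophenyl in place of 2,4-dichlorophenyl on a saturated chain carbon bound to an amine nitrogen in a ring. Going by the values given here, two steps bear on this: the halogen-to-halogen exchange a 1.1-fold lower number from compound 2 to compound 3 (0.05 log units; within the scatter) stayed within the scatter, whereas the exchange away from nitro, a 3.7-fold lower number from compound 1 to compound 3 (0.57 log units; beyond the scatter), was modest. A halogen-for-halogen swap is therefore expected to give at most a small change in this assay, a 1.4-fold higher number from compound 2 to compound 4 (0.16 log units; within the scatter), with no direction firmly indicated. Compound 4 is estimated at 2600 nM, within 1200 nM to 5600 nM.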

Compound 4, half-maximal effective concentration: 2000 nM
Compound 4: middle estimate off by 1.3-fold (0.11 log units), on the high side; the range from low to high includes it.
By their numbers in this assay, from the lowest: compounds 3, 2 and 4 (each within the scatter of the next); then compound 1.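

In this assay, the 2,4-difluorophenyl group is not separated from the other halogenated aryl groups at this position: a 1.1-fold higher number from compound 2 to compound 4 (0.05 log units; within the scatter) and a 1.3-fold higher number from compound 3 to compound 4 (0.10 log units; within the scatter) both stay within the scatter. Fluoro in place of nitro on the aromatic carbon gives a 3.0-fold lower number from compound 1 to compound 4 (0.47 log units; beyond the scatter), so compound 1 now stands apart from all three halogen compounds. No measured evidence accounts for this separation. Still open, as far as these compounds go, is whether an amine or a carboxylic acid on that aromatic carbon would shift the number beyond the scatter of the halogen compounds.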